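The source may report more compounds than this note shows. Statements on the series, on what has been measured and on what is new or still open speak of the compounds shown alone.

Measured in a functional assay on cells (Tumor Cell line, Homo sapiens) for antiproliferative activity; a higher number here means a weaker inhibitor of growth, a lower number a stronger inhibitor of growth:
- compound 1 `Cc1ccnc2nc(-c3cccc4ccccc34)cc(O)c12`: 35.5 nM
- compound 2 `Cc1cc(C)c2c(O)cc(-c3cccc4ccccc34)nc2n1`: 1050 nM

Of these two, compound 2 has the higher number, so it is the weaker inhibitor of growth. Compound 3 `Cc1ccc2c(O)cc(-c3cccc4ccccc34)nc2n1` has not yet been measured. It departs from compound 2 by one change, hydrogen in place of methyl on an aromatic carbon, opposite the ring nitrogen.

For the measured compounds named here, only one measured step bears on this, and it does so indirectly: a 30-fold higher number from compound 1 to compound 2 (1.47 log units; beyond the scatter). That step added a methyl at a different place. Compound 3 loses the methyl that compound 1 retains, and it keeps the methyl that compound 1 lacks. The effect of removing this particular methyl has not been measured. Even so, compound 2 at 1050 nM shows that a second methyl can coincide with a large loss, so a lower number is expected for compound 3, though probably not a full return to the level of compound 1. The expected change is a 5.3-fold lower number from compound 2 to compound 3 (0.72 log units; beyond the scatter). The estimate for compound 3 is 200 nM, with an expected range of 40 nM to 900 nM.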

Compound 3, concentration for 50% growth inhibition: 66.1 nM
Compound 3: the middle estimate sits 3.0-fold (0.48 log units) above what was measured, within the range that was stated.
By their numbers in this assay, from the lowest: compounds 1 and 3 (each within the scatter of the next); then compound 2.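

In this assay, the methyl opposite the ring nitrogen proves to matter as much as the other methyl: removing it gives a 16-fold lower number from compound 2 to compound 3 (1.20 log units; beyond the scatter) and thus a large gain in growth inhibition. The earlier step, a 30-fold higher number from compound 1 to compound 2 (1.47 log units; beyond the scatter), came from adding the other methyl, so it could not show what this one does. Read together, the two steps show that removing either methyl from compound 2, the only compound here that carries both, lowers the number well beyond the scatter, so the weak result of compound 2 cannot be pinned on one methyl alone; no measurement available here explains why this is so.

Still open, going by these compounds, is whether the loss depends on having both methyls in place or on the size of what sits at this carbon, which an ethyl group, a methoxy group or a chlorine atom opposite the ring nitrogen would begin to test. On these data alone, it is also open how the shared core behaves with hydrogen at both of these carbons, or with an amine in place of either methyl.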